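An Extra Chloro on the Thiourea Aryl Ring

The source may hold more compounds than are shown below. What is called first, only, known or untested is meant among the compounds shown, and "the series" means these compounds.

Measured compounds:
compound 1, `CNC(=O)c1ccc(Oc2cccc(NC(=S)Nc3ccc(Cl)cc3)c2)nc1`, 28400 nM
compound 2, `CNC(=O)c1ccc(Oc2cccc(NC(=S)Nc3ccc(C)c(C)c3)c2)nc1`, 67400 nM
compound 3, `CNC(=O)c1ccc(Oc2cccc(NC(=S)Nc3cc(C(F)(F)F)cc(C(F)(F)F)c3)c2)nc1`, 5860 nM

In a functional assay on PC-3 cells (Homo sapiens) for antiproliferative activity, read by MTT assay (a higher number here means a weaker inhibitor, a lower number a stronger inhibitor), compound 1 gives 28400 nM, the second highest of the three numbers. Compound 2 gives 67400 nM, and the step of a 2.4-fold higher number from compound 1 to compound 2 (0.38 log units; beyond the scatter) lies beyond the scatter. Compound 3 gives 5860 nM, the lowest number of the set.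

Compound 4, `CNC(=O)c1ccc(Oc2cccc(NC(=S)Nc3ccc(Cl)cc3Cl)c2)nc1`, differs from compound 1 by chloro in place of hydrogen on an aromatic carbon. Going by the values given here, no measured step adds a substituent while keeping the existing chloro, so the only guide is indirect: compound 3, which carries two substituents on that ring, shows a lower number than compound 1, while compound 2, with two methyl groups, shows a higher one. A second chloro is therefore expected to leave the number near that of compound 1 or pull it modestly down, within the step of a 1.8-fold lower number from compound 1 to compound 4 (0.25 log units; within the scatter). Compound 4 is estimated at 16000 nM, with a likely range from 5000 nM to 45000 nM.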

Compound 4, half-maximal inhibitory concentration: 19300 nM
The estimate for compound 4 lay 1.2-fold (0.08 log units) below the measured number; low and high end bracket the measured number.
By their numbers in this assay, from the lowest: compound 3; then compounds 4 and 1 (each within the scatter of the next); then compound 2.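

In this assay, going by these compounds alone, chloro in place of hydrogen on an aromatic carbon, ortho to a large group, is the first change here that keeps the existing chloro of the 4-chlorophenyl group, and it gives a 1.5-fold lower number from compound 1 to compound 4 (0.17 log units; within the scatter), so this added chloro leaves compound 4 indistinguishable from compound 1. The 2,4-dichlorophenyl group in place of 3,4-dimethylphenyl gives a 3.5-fold lower number from compound 2 to compound 4 (0.54 log units; beyond the scatter), so compound 2 stays apart from compound 4 as well as from compound 1. Nothing available here accounts for either step.

The compounds shown leave open whether a methoxy group or an amine at this same place would give a number apart from that of compound 1. They also leave open whether chloro at this place would give a step beyond the scatter on the aryl rings of compound 2 or compound 3.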